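Extending the Amide Chain from Compound 2 to Compound 3

The compounds below may be only part of what the source reports. "The series", "measured", "known", "first", "only" and "open" are said of these compounds alone.

Compound 1 `CCNC(=O)CC[C@H](NS(=O)(=O)c1ccc([N+](=O)[O-])cc1)C(=O)O` gives 89400 nM
Compound 2 `CCCCNC(=O)CC[C@H](NS(=O)(=O)c1ccc([N+](=O)[O-])cc1)C(=O)O` gives 94000 nM
Compound 3 `CCCCCNC(=O)CC[C@H](NS(=O)(=O)c1ccc([N+](=O)[O-])cc1)C(=O)O` has no value yet

In a functional assay on U-937 cells (Homo sapiens) for cytotoxicity, read by MTT assay, with a stated time of 48 h (a lower number here means a stronger inhibitor, a higher number a weaker inhibitor), compound 2 gives 94000 nM and compound 1 gives 89400 nM, so the two stand level within the scatter. The next change, from compound 2 to compound 3, puts methyl in place of hydrogen on a saturated chain carbon, four bonds along the chain from an amide-type nitrogen. Cut one bond further out, the same difference reads propyl to butyl. Among the measured compounds shown here, only one measured step bears on it. That step placed ethyl in place of hydrogen on a saturated chain carbon, two bonds along the chain from an amide-type nitrogen, and it came out as a 1.1-fold higher number from compound 1 to compound 2 (0.02 log units; within the scatter). One step is thin evidence, but it gives no reason to expect a shift beyond the scatter in this assay for the smaller addition. The expected result is a 1.0-fold lower number from compound 2 to compound 3 (0.00 log units; within the scatter). For compound 3 the estimated value is 93000 nM, with an expected range from 52000 nM to 165000 nM.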

Compound 3, half-maximal inhibitory concentration: 32100 nM
For compound 3 the middle estimate is 2.9-fold (0.46 log units) above the measured one; the measured number lies below the stated range.
By their numbers in this assay, from the lowest: compound 3; then compounds 1 and 2 (each within the scatter of the next).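

In this assay this position did not behave as the earlier pair suggested: a 1.1-fold higher number from compound 1 to compound 2 (0.02 log units; within the scatter) had left the number unmoved, yet methyl in place of hydrogen on a saturated chain carbon, four bonds along the chain from an amide-type nitrogen, gave a 2.9-fold lower number from compound 2 to compound 3 (0.47 log units; beyond the scatter) as a modest but real step. So a single added carbon at the end of the chain separated compound 3 from compound 2, while the larger ethyl addition had separated nothing, and the response to chain length in these three compounds is not even. Read from the shortest chain, the overall step is a 2.8-fold lower number from compound 1 to compound 3 (0.44 log units; beyond the scatter), and nothing at hand explains why the change appears only at this length.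

The compounds shown leave open whether a longer chain such as hexyl or octyl would lower the number further or reverse the step. They also leave open whether a branched chain, or a chain ending in an amine or a carboxylic acid, would keep the lower number seen with compound 3.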